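This account rests on a few compounds, and the source may have more. Where it says the series, first, only, none or still open, it means among the compounds named here.

Measured so far in a functional assay on PC-3M cells (Homo sapiens) for cytotoxicity, read by MTT assay, with a stated time of 48 h; a higher number here means a weaker inhibitor, a lower number a stronger inhibitor:
compound 1 `C#CCSc1nnc(CC)n1N1C(=O)c2ccccc2C1=O`, > 200000 nM
compound 2 `COc1cc(-c2nnc(SC)n2N2C(=O)c3ccccc3C2=O)cc(OC)c1OC`, > 200000 nM

For compound 2 the reading is a limit of the assay, not a number. For compound 1 the reading is likewise a limit. Both sit at the limit of > 200000 nM in this assay, at which 2 of the 2 values shown sit, so no step between measured compounds can be drawn, and compound 2 stands only at that limit, with nothing on the numbers shown separating it from compound 1. Compound 3 `COc1cc(-c2nnc(SCC(=O)c3ccc(F)c(F)c3)n2N2C(=O)c3ccccc3C2=O)cc(OC)c1OC` differs from compound 2 in one place: (3,4-difluorophenyl)carbonyl in place of hydrogen on a saturated chain carbon bound to a sulfur. Among the compounds with values here, no measured step covers a change of this kind, and the two measured values give no direction for it. The step is expected to run toward stronger inhibition, an at least 3.3-fold lower number from compound 2 to compound 3 (0.52 log units; beyond the scatter), while a sizeable chance remains that only a limit is reported again. Compound 3 is estimated at 60000 nM, with a range of 10000 nM to 200000 nM.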

Compound 3, half-maximal inhibitory concentration: 163000 nM
The estimate for compound 3 lay 2.7-fold (0.43 log units) below the measured number; measured number inside the range.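

Within the data shown here, on the saturated chain carbon bound to a sulfur, (3,4-difluorophenyl)carbonyl gives the only reading in this assay that is a number and not a limit, with compound 3 at 163000 nM. From the compounds shown here alone, the step reads an at least 1.2-fold lower number from compound 2 to compound 3 (0.08 log units; that floor lies within the scatter), and its true size stays open because the reading on one side of it is a limit: the limit of > 200000 nM in this assay, at which 2 of the 3 values shown sit. The position accepts an entering group of 10 heavy atoms, with one six-membered aromatic ring, and the reading still comes off the limit.

The compounds shown do not separate the carbonyl from the fluorinated ring; an unsubstituted phenylcarbonyl or a plain benzyl group at the same place would bear on that. Going by these compounds, whether an amine, a carboxylic acid or a longer chain there gives a reading off the limit also remains open.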